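Naphthalen-2-yl in Place of 4-Methoxyphenyl: an Estimate

The compounds below may be only part of what the source reports. "The series", "measured", "known", "first", "only" and "open" are said of these compounds alone.

Measured compounds:
compound 1 `COc1ccc(-c2cc(-c3ccc(Cl)cc3)n(C3C(=O)Nc4ccc(Br)cc43)n2)cc1` — 7200 nM
compound 2 `COc1ccc(-c2cc(-c3ccc(Cl)cc3)n(C3C(=O)Nc4ccc(Cl)cc43)n2)cc1` — 6150 nM

For the measured compounds named here, in a functional assay on cells (Cancer cell lines, Homo sapiens) for cytotoxicity, read by sulforhodamine B assay, with a stated time of 48 h (on this read-out lower numbers stand for stronger inhibition of growth and higher numbers for weaker inhibition of growth), compound 1 gives 7200 nM, the highest of the two numbers so far; its nearest neighbour, compound 2, gives 6150 nM. Going by the values given here, the one measured step, a 1.2-fold lower number from compound 1 to compound 2 (0.07 log units; within the scatter), is a halogen swap on the shared core and is within the scatter. Compound 3 `O=C1Nc2ccc(Br)cc2C1n1nc(-c2ccc3ccccc3c2)cc1-c1ccc(Cl)cc1` differs from compound 1 at a different place: naphthalen-2-yl in place of 4-methoxyphenyl on an aromatic carbon. Among the compounds with values here, no measured pair changes the group at this position, so the halogen step bears on it only in showing that the core tolerates small edits without a shift beyond the scatter. Within the data shown here, with no directly relevant step, the estimate for compound 3 is a 1.0-fold lower number from compound 1 to compound 3 (0.01 log units; within the scatter), that is, no change beyond the scatter, while the range is kept wide because the swapped group is larger than any change measured here. Compound 3 is therefore expected to give about 7000 nM, between 2500 nM and 20000 nM.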

Compound 3, concentration for 50% growth inhibition: 4330 nM
For compound 3 the middle estimate is 1.6-fold (0.21 log units) above the measured one; the measured number falls inside the stated range.
By their numbers in this assay, from the lowest: compounds 3, 2 and 1 (each within the scatter of the next).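

In this assay, for the compounds shown here, the step at this position, a 1.7-fold lower number from compound 1 to compound 3 (0.22 log units; within the scatter), gives the first measured reading of a change on this aromatic carbon of the five-membered aromatic ring with 2 nitrogen. It shows that 4-methoxyphenyl can give way to naphthalen-2-yl, with its 2 six-membered aromatic rings of carbon only and no hydrogen-bond acceptor, without a shift beyond the scatter, so in this pair the oxygen of the leaving group is not needed to keep the number where it stands. Nothing measured here offers an explanation for this outcome.

The compounds shown leave open whether a group carrying an amine or a carboxylic acid at this position would move the number beyond the scatter. They also leave open how the shared core responds to replacing the 4-chlorophenyl group, for example with a pyridine ring.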